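Oxan-4-yl in Place of Ethyl: Expecting Continued Tolerance

The compounds below may be only part of what the source reports. "The series", "measured", "known", "first", "only" and "open" are said of these compounds alone.

Compound 1 `CCCn1nc(C(=O)N[C@H]2COc3ccccc3N(C)C2=S)nc1Cc1ccccc1` was tested in a toxicity assay on HT-29 cells (Homo sapiens) for cytotoxicity; a higher number here means that more compound is tolerated, a lower number that less compound is tolerated. In this assay compound 1 gives > 100000 nM, which is a limit of the assay rather than a number. Compound 2 `CN1C(=S)[C@@H](NC(=O)c2nc(Cc3ccccc3)n(CCCCCC#N)n2)COc2ccccc21` in this assay gives > 100000 nM, also a limit. Compound 3 `CN1C(=S)[C@@H](NC(=O)c2nc(Cc3ccccc3)n(C3CCCCCC3)n2)COc2ccccc21` in this assay gives > 100000 nM, again a limit. Because the limit of > 100000 nM in this assay, at which 3 of the 3 values shown sit, none of the steps among these three can be sized: a step that the two limits leave unreadable from compound 1 to compound 2, a step that the two limits leave unreadable from compound 1 to compound 3 and a step that the two limits leave unreadable from compound 2 to compound 3. Compound 4 `CN1C(=S)[C@@H](NC(=O)c2nc(Cc3ccccc3)n(CC3CCOCC3)n2)COc2ccccc21` carries a different group on the side chain: oxan-4-yl in place of ethyl on a saturated chain carbon bound to an aromatic nitrogen. Changes at this aromatic nitrogen left every measured compound at the limit, so compound 4 is expected to stay there too, with a number no higher from compound 1 to compound 4 (the limit leaves the size open) meaning no readable step. The expected value for compound 4 in this assay is 100000 nM, ranging from 40000 nM to 300000 nM.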

Compound 4, half-maximal cytotoxic concentration: > 100000 nM
Compound 4: a limit, no number; the forecaster's own chance of this, stated with the estimate: 80%; the middle value lies on the limit itself.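

In this assay compound 4 gives > 100000 nM as a limit, not a number. Within the data shown here, no step from compound 1, compound 2 or compound 3 to compound 4 can be read, as all four compounds rest at the same limit: the limit of > 100000 nM in this assay, at which 4 of the 4 values shown sit. The compounds shown leave open how much of each compound is tolerated beyond this limit.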